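A few compounds are considered here, and "the series" means these few. Any claim that something is new, unique, unknown or untested is made for them only; others in the source may bear on it.

In a functional assay on EOL1 cells (Homo sapiens) for antiproliferative activity (on this read-out higher numbers stand for weaker inhibition and lower numbers for stronger inhibition), compound 1 (`C/C=C/Cn1cc(-c2ccc(C(=O)N3CCOCC3)c(Cl)c2)n2cncc2c1=O`) gives 8170 nM with morpholin-4-yl on the carbonyl carbon and compound 2 (`C/C=C/Cn1cc(-c2ccc(C(=O)N3CCCC3)c(Cl)c2)n2cncc2c1=O`) gives 5820 nM with pyrrolidin-1-yl in that place. Compound 2 therefore stands level with compound 1, and the two are separated only by scatter. Compound 3 (`C/C=C/Cn1cc(-c2ccc(C(=O)N3CCC(C(N)=O)CC3)c(Cl)c2)n2cncc2c1=O`) changes the same place on compound 2 (4-carbamoylpiperidin-1-yl in place of pyrrolidin-1-yl on a carbonyl carbon) and puts 4-carbamoylpiperidin-1-yl on the carbonyl carbon. For the measured compounds named here, only one measured step bears on this change (a 1.4-fold lower number from compound 1 to compound 2 (0.15 log units; within the scatter)) and it involves no group carrying a carbamoyl, so the guidance is thin. Going by the values given here, with that single small step as the only evidence, no clear shift is expected. The expected move (a 1.1-fold higher number from compound 2 to compound 3 (0.05 log units; within the scatter)) stays within the scatter, though with wide uncertainty. For compound 3 the estimated value is 6500 nM (from 2500 nM to 15000 nM).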

Compound 3, half-maximal inhibitory concentration: 3420 nM
Compound 3: the middle estimate sits 1.9-fold (0.28 log units) above what was measured; the range from low to high includes it.
By their numbers in this assay, from the lowest: compounds 3, 2 and 1 (each within the scatter of the next, the first and the last beyond it).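

In this assay, the position on the carbonyl carbon accepts the larger 4-carbamoylpiperidin-1-yl, with its hydrogen-bond donor, in place of pyrrolidin-1-yl at no measurable cost, as a 1.7-fold lower number from compound 2 to compound 3 (0.23 log units; within the scatter) shows. For the compounds shown here, the comparison with morpholin-4-yl gives the first change at this position that clears the scatter, though only modestly: a 2.4-fold lower number from compound 1 to compound 3 (0.38 log units; beyond the scatter). No measurement available here explains this difference.

The compounds shown leave open whether the separation from compound 1 goes with the six-membered ring or with the carbamoyl group. A plain piperidin-1-yl, or a piperidine carrying a carboxylic acid or an amine in place of the carbamoyl, would help to tell these apart.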